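Changing the amide-nitrogen group: compound 3 to compound 4

The source may report more compounds than this note shows. Statements on the series, on what has been measured and on what is new or still open speak of the compounds shown alone.

In a functional assay on Shh Light II cells (Mus musculus) for inhibition, read by a luciferase reporter (a lower number here means a stronger inhibitor, a higher number a weaker inhibitor), compound 3 (`CC(=O)N1CCC(NC(=O)N2CCC(c3nc(-c4ccc5ccccc5n4)no3)CC2)CC1`) gives 500 nM and compound 1 (`CC(C)c1ccccc1NC(=O)N1CCC(c2nc(-c3ccc4ccccc4n3)no2)CC1`) gives 480 nM. These two values sit together: a 1.0-fold higher number from compound 1 to compound 3 (0.02 log units; within the scatter). Compound 2 (`O=C(N1CCC(c2nc(-c3ccc4ccccc4n3)no2)CC1)N1CCCc2ccccc21`) gives 2300 nM and stands apart: a 4.6-fold lower number from compound 2 to compound 3 (0.66 log units; beyond the scatter).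

Compound 4 (`O=C(NC1CCOCC1)N1CCC(c2nc(-c3ccc4ccccc4n3)no2)CC1`) carries one change: oxan-4-yl in place of 1-acetylpiperidin-4-yl on an amide-type nitrogen. This places oxan-4-yl in place of 1-acetylpiperidin-4-yl on an amide-type nitrogen. The closest evidence is the earlier exchange on that same nitrogen, where 1-acetylpiperidin-4-yl replaced 2-isopropylphenyl with no step beyond the scatter. Among the compounds with values here, the only larger step at this end of the series, a 4.8-fold higher number from compound 1 to compound 2 (0.68 log units; beyond the scatter), put 1,2,3,4-tetrahydroquinolin-1-yl on the carbonyl carbon, an exchange that compound 4 does not share. Within the data shown here, no measured compound carries oxan-4-yl, so the reading rests on three values alone.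

No step beyond the scatter is therefore expected in this assay. The estimated step is a 1.1-fold higher number from compound 3 to compound 4 (0.04 log units; within the scatter). For compound 4 the expected value is 550 nM, with an estimated range of 220 nM to 1400 nM.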

Compound 4, half-maximal inhibitory concentration: 480 nM
Beside the measured number, compound 4's estimate is 1.1-fold (0.06 log units) above it, within the range that was stated.
By their numbers in this assay, from the lowest: compounds 1, 4 and 3 (each within the scatter of the next); then compound 2.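

In this assay, oxan-4-yl in place of 1-acetylpiperidin-4-yl gives a 1.0-fold lower number from compound 3 to compound 4 (0.02 log units; within the scatter), and oxan-4-yl in place of 2-isopropylphenyl gives no change at the digits printed from compound 1 to compound 4 (within the scatter), so three different groups on this amide-type nitrogen now sit together, including one with fewer heavy atoms and no double bond outside aromatic rings. Compound 2 stays apart from this group, with a 4.8-fold lower number from compound 2 to compound 4 (0.68 log units; beyond the scatter) on exchanging 1,2,3,4-tetrahydroquinolin-1-yl for (oxan-4-yl)amino on the carbonyl carbon. No supporting data explain these values.

Open, going by these compounds, is whether the same level holds on this nitrogen with a piperidin-4-yl bearing a free ring amine, a carboxylic acid or a short open alkyl chain. Also open, on these data alone, is whether other ring groups on the carbonyl carbon follow compound 2.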